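Swapping the sulfonyl aryl group from compound 3 to compound 4

A few compounds are considered here, and "the series" means these few. Any claim that something is new, unique, unknown or untested is made for them only; others in the source may bear on it.

Compound 3 `COc1ccc(S(=O)(=O)c2cnc3cc(F)ccc3c2-c2ccc(F)cc2)cc1Cl` is the middle member of a small set of three. In an ADME assay on microsomes from liver (Homo sapiens) for metabolic stability, tested at 2.5 uM (on this read-out lower numbers stand for slow clearance and higher numbers for fast clearance), compound 3 gives 1.29 mL/min. Compound 1 `COc1cccc(-c2c(S(=O)(=O)c3ccc(OC)c(Cl)c3)cnc3cc(F)ccc23)c1` gives 1.71 mL/min in this assay, and the step of a 1.3-fold lower number from compound 1 to compound 3 (0.12 log units; within the scatter) shows that the two sit close together. Compound 2 `O=S(=O)(c1cc(Cl)cc(Cl)c1)c1cnc2cc(F)ccc2c1-c1ccc(F)cc1` gives 0.18 mL/min, and the step of a 7.2-fold higher number from compound 2 to compound 3 (0.86 log units; beyond the scatter) separates it clearly from compound 3, so compound 3 stands second highest of the three numbers, with compound 1 nearest and compound 2 furthest.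

Compound 4 `Cc1ccc(S(=O)(=O)c2cnc3cc(F)ccc3c2-c2ccc(F)cc2)cc1F` is not yet measured. Its change from compound 3 is 3-fluoro-4-methylphenyl in place of 3-chloro-4-methoxyphenyl on a sulfonyl sulfur.

For the measured compounds named here, the only measured step that touches the same place is the one from compound 2 to compound 3, which was modest and ran upward. Compound 4 also drops the methoxy group that compound 3 carries, yet it does not return to the dichlorophenyl of compound 2, so the step is expected to fall short of that earlier one. Compound 4 is therefore estimated to lie below compound 3, with an expected step of a 2.2-fold lower number from compound 3 to compound 4 (0.33 log units; beyond the scatter). Compound 4 is expected to give about 0.6 mL/min in this assay, within a range from 0.2 mL/min to 1.8 mL/min.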

Compound 4, intrinsic clearance in a liver preparation (reported as CLH), per the amount of preparation that the assay uses: 2.33 mL/min
Compound 4: middle estimate off by 3.9-fold (0.59 log units), on the low side; measured number above the stated range.
By their numbers in this assay, from the lowest: compound 2; then compounds 3, 1 and 4 (each within the scatter of the next).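

In this assay, the step of a 1.8-fold higher number from compound 3 to compound 4 (0.26 log units; within the scatter) does not tell the two compounds apart, even though the 3-fluoro-4-methylphenyl group on the sulfonyl sulfur shares neither the chlorine nor the methoxy group of the 3-chloro-4-methoxyphenyl group it replaces. The step of a 13-fold higher number from compound 2 to compound 4 (1.11 log units; beyond the scatter) is large, so the gap from compound 2 that the earlier compounds showed only with a methoxy-bearing group also appears without one, and among the three aryl groups shown on this sulfur, only the 3,5-dichlorophenyl of compound 2 stands apart. Nothing shown here gives a reason for this difference.

The exchange from compound 3 to compound 4 alters the halogen and the other substituent together, so the compounds shown cannot separate what fluorine in place of chlorine does from what methyl in place of methoxy does. They also leave open how the number would respond to an amine or a carboxylic acid on this aryl group, or to an unsubstituted phenyl on the sulfonyl sulfur.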